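The source may hold more compounds than are shown below. What is called first, only, known or untested is meant among the compounds shown, and "the series" means these compounds.

Compound 1, `NC(=O)c1c(NC(=O)c2ccc(C(F)(F)F)cc2)sc2c1CCN(Cc1ccc(Cl)cc1Cl)C2`, is the starting point. In a functional assay on HL-60 cells (Homo sapiens) for antiproliferative activity, with a stated time of 24 h (a higher number here means a weaker inhibitor, a lower number a stronger inhibitor), compound 1 gives 14900 nM. Compound 2, `Cc1ccc(C(=O)Nc2sc3c(c2C(N)=O)CCN(Cc2ccc(Cl)cc2Cl)C3)cc1`, carries one change relative to compound 1: methyl in place of trifluoromethyl on an aromatic carbon. In this assay compound 2 gives 19900 nM, and the step is a 1.3-fold higher number from compound 1 to compound 2 (0.13 log units; within the scatter). Compound 3, `NC(=O)c1c(NC(=O)c2ccc(C(F)(F)F)cc2)sc2c1CCN(C(=S)Nc1ccccc1Cl)C2`, keeps the trifluoromethyl but alters the ring nitrogen substituent: a group of 10 heavy atoms (7 carbon, 1 nitrogen, 1 sulfur, 1 chlorine; one six-membered aromatic ring of carbon only) in place of a group of 9 heavy atoms (7 carbon, 2 chlorine; one six-membered aromatic ring of carbon only), on an amine nitrogen in a ring. In this assay compound 3 gives 36100 nM, a step of a 2.4-fold higher number from compound 1 to compound 3 (0.38 log units; beyond the scatter). Compound 4, `Cc1ccc(C(=O)Nc2sc3c(c2C(N)=O)CCN(C(=S)Nc2ccccc2Cl)C3)cc1`, repeats on the core of compound 3 the change seen between compound 1 and compound 2: methyl in place of trifluoromethyl on an aromatic carbon. The place of the change is the same in both pairs, so the same change is made on a different core. Because the measured step was a 1.3-fold higher number from compound 1 to compound 2 (0.13 log units; within the scatter), a similarly small step is expected here, a 1.3-fold higher number from compound 3 to compound 4 (0.11 log units; within the scatter). Compound 4 is therefore estimated at 47000 nM, roughly between 22000 nM and 100000 nM.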

Compound 4, half-maximal inhibitory concentration: 8430 nM
The estimate for compound 4 lay 5.6-fold (0.75 log units) above the measured number, outside the stated range (below it).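

In this assay, putting methyl in place of trifluoromethyl gives a 4.3-fold lower number from compound 3 to compound 4 (0.63 log units; beyond the scatter), and this step does not match the one seen on the other core: the same change on two cores in this assay, a 1.3-fold higher number (0.13 log units; within the scatter) from compound 1 to compound 2 and a 4.3-fold lower number (0.63 log units; beyond the scatter) from compound 3 to compound 4, 5.7-fold (0.76 log units) apart, beyond the scatter of two such steps The change on the ring nitrogen also depends on its partner, giving a 2.4-fold lower number from compound 2 to compound 4 (0.37 log units; beyond the scatter), which differs from its earlier counterpart: the same change on two cores in this assay, a 2.4-fold higher number (0.38 log units; beyond the scatter) from compound 1 to compound 3 and a 2.4-fold lower number (0.37 log units; beyond the scatter) from compound 2 to compound 4, 5.7-fold (0.76 log units) apart, beyond the scatter of two such steps These four compounds therefore show that the two changes do not act independently of each other here, but they do not show why, nor whether this holds for other groups or cores. The compounds shown leave open how a methoxy group or a carboxylic acid in place of the methyl would behave on each core.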